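A small change on the amine: does toxicity move?

The source may report more compounds than this note shows. Statements on the series, on what has been measured and on what is new or still open speak of the compounds shown alone.

The three measured compounds share one core and differ only in the group carried on the ring nitrogen. Compound 1 `CC(C)C(Nc1nc(Cl)nc2c1ncn2[C@H]1[C@H](O)[C@H](O)[C@]2(CO)C[C@H]12)C(C)C` was tested in an ADME assay on Vero 76 cells (Chlorocebus sabaeus) for cytotoxicity, read by neutral red uptake (on this read-out lower numbers stand for higher toxicity in this test and higher numbers for lower toxicity in this test), and in this assay compound 1 gives > 100000 nM, which is a limit of the assay rather than a number. Compound 2 `CC(C)(O)[C@@H](Nc1nc(Cl)nc2c1ncn2[C@H]1[C@H](O)[C@H](O)[C@]2(CO)C[C@H]12)C1CC1` likewise gives > 100000 nM, again a limit and not a number. Compound 3 `CC(C)[C@@H](Nc1nc(Cl)nc2c1ncn2[C@H]1[C@H](O)[C@H](O)[C@]2(CF)C[C@H]12)C1CC1` gives 33000 nM. Compound 2 therefore stands at the limit, as does compound 1, and only compound 3 returns a number. Among the compounds with values here, the one step between single-change neighbours, a step that the two limits leave unreadable from compound 1 to compound 2, cannot be sized because both of its ends sit at the limit of > 100000 nM in this assay, at which 2 of the 3 values shown sit.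

Compound 4 `CC(C)(C)[C@H](Nc1nc(Cl)nc2c1ncn2[C@H]1[C@H](O)[C@H](O)[C@]2(CO)C[C@H]12)C1CC1` has not been measured. It differs from compound 2 in one place: 1-cyclopropyl-2,2-dimethylpropyl in place of 1-cyclopropyl-2-hydroxy-2-methylpropyl on a nitrogen on an aromatic ring. No measured step covers this change; the only shown step is unreadable, and compound 3 differs from compound 2 in more than one place. With nothing pointing up or down, compound 4 is expected to remain close to compound 2. The step of a number no higher from compound 2 to compound 4 (the limit leaves the size open) is estimated to lie within the scatter. Compound 4 is estimated at 100000 nM, with a range from 30000 nM to 300000 nM, and a fair chance that the assay again reports only a limit.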

Compound 4, half-maximal cytotoxic concentration: > 100000 nM
Compound 4 ended at the assay's limit (the forecaster's own chance of this, stated with the estimate: 60%); the middle value lies on the limit itself.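

In this assay compound 4 gives > 100000 nM, which is a limit and not a number. Compound 1, compound 2 and compound 4 all sit at this limit, so no step among them can be read: the limit of > 100000 nM in this assay, at which 3 of the 4 values shown sit.

The compounds shown leave open whether the groups on the nitrogen of these three compounds differ at all in toxicity in this assay.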